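Swapping isopropyl for 2,2,2-trifluoroethyl in compound 4

The compounds below may be only part of what the source reports. "The series", "measured", "known", "first", "only" and "open" are said of these compounds alone.

Measured so far in an ADME assay on BJ cells (Homo sapiens) for cytotoxicity, with a stated time of 72 h (on this read-out lower numbers stand for an effect already at smaller amounts and higher numbers for an effect only at larger amounts of compound), for three compounds:
- Compound 1 `COc1cc2ncnc(-n3nc(-c4ccccn4)nc3N)c2cc1OCc1ccccc1` gives > 27000 nM as a limit.
- Compound 2 `COc1cc2ncnc(-n3nc(-c4ccccn4)nc3N)c2cc1OCCCNC(=O)CN1C[C@@H](C)O[C@@H](C)C1` gives > 25000 nM as a limit.
- Compound 3 `COc1cc2ncnc(-n3nc(-c4ccccn4)nc3N)c2cc1OCCCNC(=O)OC(C)C` gives > 13000 nM as a limit.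

Compound 3 stands at > 13000 nM and this is only a limit. The values of the other two compounds are limits as well, so no number is available in this assay for any of the three.

Compound 4 `COc1cc2ncnc(-n3nc(-c4ccccn4)nc3N)c2cc1OCCCNC(=O)OCC(F)(F)F` differs from compound 3 in one place, where 2,2,2-trifluoroethyl takes the place of isopropyl on an oxygen next to a carbonyl group. The count of that change is 2,2,2-trifluoroethyl in place of isopropyl on an oxygen next to a carbonyl group and nothing else in the structure differs.

For the measured compounds named here, two measured steps bear on this part of the molecule. Going by the values given here, the first is a step that the two limits leave unreadable from compound 1 to compound 3 and the second is a step that the two limits leave unreadable from compound 2 to compound 3 and neither gives a size to carry over. No step beyond the usual scatter is therefore expected in this assay and no direction is favoured. The expected change is a step that the limit leaves unreadable from compound 3 to compound 4 on this reasoning. For compound 4 the expected value is 20000 nM with an estimated range from 9000 nM to 45000 nM as the likely span.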

Compound 4, half-maximal effective concentration: > 11000 nM
Compound 4: a limit, no number (the forecaster's own chance of this, stated with the estimate: 80%); the middle value is on the limit's open side.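

In this assay compound 4 returns only a limit, as do compound 1, compound 2 and compound 3, so no step can be read between any of these four compounds. The compounds shown leave open whether 2,2,2-trifluoroethyl in place of isopropyl changes the read-out at all, and in which direction.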